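The source may report more compounds than this note shows. Statements on the series, on what has been measured and on what is new or still open speak of the compounds shown alone.

Among the measured compounds shown here, compound 2, `COc1ccc(C(=O)/C=C/c2cc(-c3cc(OC)c(OC)c(OC)c3)n[nH]2)cc1OC`, stands at the lowest of the two numbers so far: in a functional assay on NCI-H322M cells (Homo sapiens) for inhibition, read by sulforhodamine B assay, with a stated time of 48 h (on this read-out higher numbers stand for weaker inhibition of growth and lower numbers for stronger inhibition of growth), compound 2 gives 1520 nM. For the measured compounds named here, its only neighbour is compound 1, `COc1cc(-c2cc(/C=C/C(=O)c3ccc(Cl)c(Cl)c3)[nH]n2)cc(OC)c1OC`, which in this assay gives 14500 nM. Going by the values given here, the single measured step links these two: a 9.5-fold lower number from compound 1 to compound 2 (0.98 log units; beyond the scatter).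

Compound 3, `COc1ccc(C(=O)/C=C/c2cc(-c3cc(OC)c(OC)c(OC)c3)n[nH]2)cc1`, differs from compound 2 by hydrogen in place of methoxy on an aromatic carbon. Among the compounds with values here, no measured step removes a methoxy from this ring, so the one step on record bears only loosely: it tells that the substitution pattern of the aryl group on the carbonyl carbon can move the number by a modest amount, but it does not show what dropping one methoxy alone does. With the aryl group on the carbonyl carbon otherwise kept, the expectation is a small step, if any, most likely toward a somewhat higher number, and it may well stay within the scatter. The expected step is therefore a 2.0-fold higher number from compound 2 to compound 3 (0.30 log units; within the scatter). Compound 3 is estimated to give 3000 nM in this assay, within a range from 1000 nM to 9000 nM.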

Compound 3, concentration for 50% growth inhibition: 1920 nM
The estimate for compound 3 lay 1.6-fold (0.19 log units) above the measured number; the measured number falls inside the stated range.
By their numbers in this assay, from the lowest: compounds 2 and 3 (each within the scatter of the next); then compound 1.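

Dropping one methoxy, which turns 3,4-dimethoxyphenyl into 4-methoxyphenyl, leaves this assay essentially unmoved, with a 1.3-fold higher number from compound 2 to compound 3 (0.10 log units; within the scatter), so at this position on a six-membered aromatic ring of carbon only, the methoxy that leaves makes no difference that can be told apart from the scatter. The second new step, a 7.6-fold lower number from compound 1 to compound 3 (0.88 log units; beyond the scatter), is close in size to the earlier step from the 3,4-dichlorophenyl compound to the dimethoxy compound, so among these three compounds the large gap separates the 3,4-dichlorophenyl group from both methoxy-bearing groups, and a second methoxy is not needed to reach the lower numbers. No measurement offered here gives a reason for either step.

The compounds shown leave open what the methoxy that remains contributes, and what a plain phenyl group, a hydroxyl group or an amine on that ring would give. They also leave open whether a single chlorine on the ring would sit with the 3,4-dichlorophenyl compound or with the two methoxy-bearing compounds.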